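A few compounds are considered here, and "the series" means these few. Any claim that something is new, unique, unknown or untested is made for them only; others in the source may bear on it.

Measured so far in a functional assay on HEp-2 cells (Homo sapiens) for antiproliferative activity, read by MTT assay, with a stated time of 72 h; a lower number here means a stronger inhibitor, a higher number a weaker inhibitor:
compound 1 `COc1ccc2occ(CSC(=S)N(C(C)C)C(C)C)c(=O)c2c1` gives 8900 nM
compound 2 `O=c1c(CSC(=S)N2CCOCC2)coc2cc(Cl)ccc12` gives 900 nM
compound 3 `COc1ccc2occ(CSC(=S)N3CCOCC3)c(=O)c2c1` gives 4800 nM

Compound 3 stands second highest of the three numbers in this assay. Its nearest neighbour is compound 1, and the step from compound 1 to compound 3 is a 1.9-fold lower number from compound 1 to compound 3 (0.27 log units; within the scatter), which lies within the scatter. Compound 2 gives the lowest number of the three, beyond the scatter from compound 3, but compound 2 and compound 3 differ in more than one place, so this pair is only a comparison of two values, not a single step.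

The unmeasured compound 4 `O=c1c(CSC(=S)N2CCOCC2)coc2ccccc12` differs from compound 3 by hydrogen in place of methoxy on an aromatic carbon. Among the measured compounds shown here, no measured step bears directly on this change: the only single step, a 1.9-fold lower number from compound 1 to compound 3 (0.27 log units; within the scatter), concerns the amine on the thiocarbonyl carbon, not the aromatic ring. The direction of the change is therefore open. Compound 4 is expected to show a step of a 1.2-fold lower number from compound 3 to compound 4 (0.08 log units; within the scatter), with no confident direction beyond the scatter. The estimate for compound 4 in this assay is 4000 nM, with a range from 1500 nM to 12000 nM.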

Compound 4, half-maximal inhibitory concentration: 4400 nM
For compound 4 the middle estimate is 1.1-fold (0.04 log units) below the measured one, and the stated range covers the measured number.
By their numbers in this assay, from the lowest: compound 2; then compounds 4, 3 and 1 (each within the scatter of the next, the first and the last beyond it).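

In this assay, hydrogen in place of methoxy on this aromatic carbon gives a 1.1-fold lower number from compound 3 to compound 4 (0.04 log units; within the scatter), so compound 3 and compound 4 cannot be told apart, and the methoxy shows no measurable contribution here. Among the compounds shown here, compound 4 also supplies the single step that compound 2 lacked: hydrogen in place of chloro gives a 4.9-fold higher number from compound 2 to compound 4 (0.69 log units; beyond the scatter), which ties the low number of compound 2 to its chloro, with the morpholin-4-yl group held the same. Nothing else measured explains why one substituent matters and the other does not.

From the compounds shown here alone, compound 2 and compound 3 differ in more than one place, so it remains open whether chloro on the methoxy carbon would give the same gain. Going by these compounds, it is also open whether an amine or a carboxylic acid there would move the number, or whether the chloro step holds with diisopropylamino on the thiocarbonyl carbon.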